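A few compounds are considered here, and "the series" means these few. Any claim that something is new, unique, unknown or untested is made for them only; others in the source may bear on it.

Measured so far:
compound 1, `O=c1ccc(-c2ccc3cn[nH]c3c2)cn1Cc1ccccc1C(F)(F)F`: 133 nM
compound 2, `Nc1n[nH]c2cc(-c3ccc(=O)n(Cc4cccc(F)c4)c3)ccc12`: 19 nM
compound 3, `O=c1ccc(-c2ccc3cc[nH]c3c2)cn1Cc1ccccc1`: recorded only as a limit, > 2000 nM

In an assay for inhibition of MAP kinase-interacting serine/threonine-protein kinase 1 (Homo sapiens), read by luminescence and ADP-Glo, with a stated time of 2 h (on this read-out higher numbers stand for weaker inhibition and lower numbers for stronger inhibition), compound 1 holds the highest of the two numbers given; the nearest is compound 2, whose number is lower by a margin beyond the usual scatter. Compound 3 sits at the limit of > 2000 nM in this assay, at which 1 of the 3 values shown sits, and so contributes no number to compare.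

Compound 4 is `O=c1ccc(-c2ccc3cn[nH]c3c2)cn1Cc1ccccc1Cl`, not yet measured. Against compound 1 the change is chloro in place of trifluoromethyl on an aromatic carbon.

Within the data shown here, with no measured pair covering such a change, the step from compound 1 to compound 4 is expected to be a 1.1-fold higher number from compound 1 to compound 4 (0.05 log units; within the scatter), that is, no shift beyond the scatter in either direction. Compound 4 is therefore estimated at 150 nM, with a range of 50 nM to 450 nM.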

Compound 4, half-maximal inhibitory concentration: 80 nM
The estimate for compound 4 lay 1.9-fold (0.27 log units) above the measured number; low and high end bracket the measured number.
By their numbers in this assay, from the lowest: compound 2; then compounds 4 and 1 (each within the scatter of the next). At a limit, above all of these: compound 3.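

Working from this assay, chloro in place of trifluoromethyl gives a 1.7-fold lower number from compound 1 to compound 4 (0.22 log units; within the scatter) and so the two groups cannot be told apart on this aromatic carbon. Among these compounds, replacing four heavy atoms with one therefore leaves the number within the scatter, a point the earlier compounds could not show. Nothing measured here accounts for this step.

Still open, on these data alone, is how an amine, a methoxy group or a carboxylic acid on this aromatic carbon would read. Also open, as far as these compounds go, is whether chloro and trifluoromethyl stay level on a different core.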